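Notes on the aryl swap from compound 3 to compound 4

The source may report more compounds than this note shows. Statements on the series, on what has been measured and on what is new or still open speak of the compounds shown alone.

For the measured compounds named here, the series shares one core carrying a trimethoxyphenyl ketone and an amino group; the three measured members vary only the aryl ring on the five-membered aromatic ring with 1 sulfur. In a functional assay on L1210 cells (Mus musculus) for antiproliferative activity (on this read-out higher numbers stand for weaker inhibition and lower numbers for stronger inhibition), compound 1 `COc1cc(C(=O)c2sc(-c3ccc(Cl)cc3)cc2N)cc(OC)c1OC` gives 93 nM. Compound 2 `COc1cc(C(=O)c2sc(-c3ccc(Cl)c(Cl)c3)cc2N)cc(OC)c1OC` gives 260 nM in this assay. Compound 3 `COc1cc(C(=O)c2sc(-c3ccc([N+](=O)[O-])cc3)cc2N)cc(OC)c1OC` gives 100 nM in this assay.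

The step of a 2.8-fold higher number from compound 1 to compound 2 (0.45 log units; beyond the scatter) is modest but beyond the scatter. The step of a 1.1-fold higher number from compound 1 to compound 3 (0.03 log units; within the scatter) is within the scatter, and the step of a 2.6-fold lower number from compound 2 to compound 3 (0.41 log units; beyond the scatter) is modest. On these numbers compound 3 stands second highest of three, nearest compound 1 and furthest from compound 2.

Compound 4 `COc1cc(C(=O)c2sc(-c3ccncc3)cc2N)cc(OC)c1OC` differs from compound 3 by pyridin-4-yl in place of 4-nitrophenyl on an aromatic carbon. Going by the values given here, no measured step exchanges the six-membered carbon-only ring for a ring with 1 hetero atom, so the bearing of the data is indirect: the step from compound 1 to compound 3 shows that exchanging the substituent on that ring leaves this assay unchanged within the scatter, while the step from compound 1 to compound 2 shows that a second chloro costs a modest amount. A small step, if any, is therefore expected in this assay, with the direction open. The expected step of a 1.4-fold higher number from compound 3 to compound 4 (0.15 log units; within the scatter) is within the scatter. Compound 4 is estimated at 140 nM, between 55 nM and 400 nM.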

Compound 4, half-maximal inhibitory concentration: 1810 nM
Compound 4: the middle estimate sits 13-fold (1.11 log units) below what was measured; measured number outside the range, above it.
By their numbers in this assay, from the lowest: compounds 1 and 3 (each within the scatter of the next); then compound 2; then compound 4.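

Working notes on the position next to the ring sulfur: the earlier compounds changed only the substituents on a carbon-only six-membered ring, and those changes gave steps no larger than modest. For the compounds shown here, replacing that ring with pyridin-4-yl is the first change here to give a large step, with an 18-fold higher number from compound 3 to compound 4 (1.26 log units; beyond the scatter) and a 19-fold higher number from compound 1 to compound 4 (1.29 log units; beyond the scatter), so in this assay this position discriminates far more sharply between aryl groups than the earlier steps suggested. Even against the 3,4-dichlorophenyl group, which had the highest number until now, the change gives a 7.0-fold higher number from compound 2 to compound 4 (0.84 log units; beyond the scatter), which leaves compound 4 the weakest of the four, and no supporting measurement is available to account for the loss.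

The compounds shown leave open whether the loss follows the ring nitrogen itself or the lack of any substituent on the ring, a question that an unsubstituted phenyl group would help settle. They also leave open whether the placement of the nitrogen matters, which pyridin-3-yl or pyridin-2-yl could test, and whether a substituent such as chloro on the pyridine ring would recover the lost inhibition.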